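Removing One Methoxy Group: What to Expect

The source may report more compounds than this note shows. Statements on the series, on what has been measured and on what is new or still open speak of the compounds shown alone.

Of the compounds shown here, three built on one shared core have been tested in a functional assay on ACHN cells (Homo sapiens) for inhibition, read by sulforhodamine B assay, with a stated time of 48 h; a lower number here means a stronger inhibitor of growth, a higher number a weaker inhibitor of growth. Compound 1 `COc1cc(-c2cc(/C=C/C(=O)c3ccc(N)cc3)[nH]n2)cc(OC)c1OC` gives 3670 nM in this assay. Compound 2 `COc1cc(-c2cc(/C=C/C(=O)c3ccc(Cl)c(Cl)c3)[nH]n2)cc(OC)c1OC` reaches only the limit of the assay, > 100000 nM in this assay. Compound 3 `COc1ccc(C(=O)/C=C/c2cc(-c3cc(OC)c(OC)c(OC)c3)n[nH]2)cc1OC` gives 3090 nM in this assay; its number is the lower of the two numbers available, yet a 1.2-fold lower number from compound 1 to compound 3 (0.07 log units; within the scatter), so compound 1 and compound 3 cannot be told apart. Among the other pairs, an at least 32-fold lower number from compound 2 to compound 3 (1.51 log units; beyond the scatter), and an at least 27-fold higher number from compound 1 to compound 2 (1.43 log units; beyond the scatter).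

Compound 4 `COc1ccc(C(=O)/C=C/c2cc(-c3cc(OC)c(OC)c(OC)c3)n[nH]2)cc1` is the next compound to be measured. It differs from compound 3 in one place: hydrogen in place of methoxy on an aromatic carbon. Going by the values given here, no measured step removes a methoxy group, but the two steps that alter this same ring, a 1.2-fold lower number from compound 1 to compound 3 (0.07 log units; within the scatter) and an at least 32-fold lower number from compound 2 to compound 3 (1.51 log units; beyond the scatter), show that a change here can stay within the scatter or become large. For a change as small as the loss of one methoxy group, a step of a 1.3-fold higher number from compound 3 to compound 4 (0.11 log units; within the scatter) is expected. Compound 4 is therefore estimated at 4000 nM, within 1500 nM to 12000 nM.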

Compound 4, concentration for total growth inhibition: 3630 nM
For compound 4 the middle estimate is 1.1-fold (0.04 log units) above the measured one, and the stated range covers the measured number.
By their numbers in this assay, from the lowest: compounds 3, 4 and 1 (each within the scatter of the next). At a limit, above all of these: compound 2.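

Removing this methoxy group, ortho to a methoxy group, makes no readable difference in this assay: a 1.2-fold higher number from compound 3 to compound 4 (0.07 log units; within the scatter). The 4-methoxyphenyl ring also cannot be told apart from the 4-aminophenyl ring, a 1.0-fold lower number from compound 1 to compound 4 (0.00 log units; within the scatter), so among compounds 1, 3 and 4, the number holds across a methoxy group, a second methoxy group and an amino group on this ring. Only the 3,4-dichlorophenyl ring stands apart, an at least 27-fold lower number from compound 2 to compound 4 (1.44 log units; beyond the scatter); the figure for compound 2 is a limit, not a number: the limit of > 100000 nM in this assay, at which 1 of the 4 values shown sits.

Still open, from the compounds shown here alone, is how a plain phenyl ring, a hydroxyl group in place of the methoxy group, or a single chlorine on this ring would read. The numbers also do not say why compound 2 parts from the other three.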